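The compounds below may be only part of what the source reports. "The series", "measured", "known", "first", "only" and "open" are said of these compounds alone.

Working notes on the series, read in an ADME assay on microsomes from liver (Mus musculus) for metabolic stability, read by HPLC, with a stated time of 4 h; on this read-out higher numbers stand for fast clearance and lower numbers for slow clearance. Going by the values given here, compound 1 `CN(C)c1ccc2cc(-c3cc(Cl)cc(Cl)c3)c(N)nc2c1` gives 210 mL/min/kg and compound 2 `Nc1nc2cc(N3CCCC3)ccc2cc1-c1cc(Cl)cc(Cl)c1` gives 320 mL/min/kg, which places compound 2 within the scatter of compound 1, the only other measured compound. Compound 3 `Nc1nc2cc(N3CCCCC3)ccc2cc1-c1cc(Cl)cc(Cl)c1` differs from compound 2 in one place: piperidin-1-yl in place of pyrrolidin-1-yl on an aromatic carbon. Among the compounds with values here, the one measured step bearing on this change, a 1.5-fold higher number from compound 1 to compound 2 (0.18 log units; within the scatter), stays within the scatter, so no shift beyond the scatter is expected in this assay. The expected step is a 1.1-fold higher number from compound 2 to compound 3 (0.03 log units; within the scatter). Compound 3 is estimated at 340 mL/min/kg, with an expected range of 200 mL/min/kg to 580 mL/min/kg.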

Compound 3, clearance: 460 mL/min/kg
For compound 3 the middle estimate is 1.4-fold (0.13 log units) below the measured one; low and high end bracket the measured number.
By their numbers in this assay, from the lowest: compounds 1, 2 and 3 (each within the scatter of the next, the first and the last beyond it).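

Piperidin-1-yl in place of pyrrolidin-1-yl on this aromatic carbon gives a 1.4-fold higher number from compound 2 to compound 3 (0.16 log units; within the scatter) in this assay, so this change alone cannot be told apart from the scatter. Piperidin-1-yl in place of dimethylamino gives a 2.2-fold higher number from compound 1 to compound 3 (0.34 log units; beyond the scatter), the first step at this position to pass the scatter, and only modestly. No measurement at hand explains this step.

Open, from the compounds shown here alone, is how a morpholin-4-yl group, or a piperidin-1-yl ring carrying a carboxylic acid, would read at this position.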